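Trimming one methoxy from a chalcone-like pyrazole

A few compounds are considered here, and "the series" means these few. Any claim that something is new, unique, unknown or untested is made for them only; others in the source may bear on it.

Compound 1 `COc1cc(-c2cc(/C=C/C(=O)c3ccc(N)cc3)[nH]n2)cc(OC)c1OC` is followed in a functional assay on UACC-257 cells (Homo sapiens) for cytotoxicity, read by sulforhodamine B assay, with a stated time of 48 h, tested at 100 uM (a lower number here means a stronger effect, a higher number a weaker effect of the compound at the concentration tested), against two companions. Compound 2 `COc1ccc(-c2cc(/C=C/C(=O)c3ccc(OC)c(OC)c3)[nH]n2)cc1` gives -100% in this assay, compound 3 `COc1cc(-c2cc(/C=C/C(=O)c3ccc(Cl)c(Cl)c3)[nH]n2)cc(OC)c1OC` gives -10%, and compound 1 itself gives -93%, the second highest of the three numbers. For the measured compounds named here, compound 2 sits within the scatter of compound 1, while compound 3 lies far away: the step of a number 83 percentage points higher from compound 1 to compound 3 (beyond the scatter) is the only single-place step recorded here, and it concerns the aryl group on the carbonyl carbon, not the ring carrying the methoxy groups.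

Compound 4 `COc1ccc(-c2cc(/C=C/C(=O)c3ccc(N)cc3)[nH]n2)cc1OC` is the next compound for this assay. It differs from compound 1 in one place: hydrogen in place of methoxy on an aromatic carbon. Going by the values given here, no measured step addresses this exact change. What the numbers do show is that compound 2, which carries fewer methoxy groups on the ring attached to the shared core, still gives -100%, so a less methoxylated ring on that side has not weakened the effect among these compounds. The large step seen for compound 3 arose elsewhere in the molecule. The change to compound 4 is therefore expected to stay within the scatter, with the expected step of a number 5 percentage points higher from compound 1 to compound 4 (within the scatter). Compound 4 is estimated at -88%, within the range -100% to -55%.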

Compound 4, a percentage reported as activity, at one concentration (the size of the read-out at that concentration, not a potency): -96%
Compound 4: middle estimate off by 8 percentage points, on the high side, and the stated range covers the measured number.
By their numbers in this assay, from the lowest: compounds 2, 4 and 1 (each within the scatter of the next); then compound 3.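

In this assay, the step is a number 3 percentage points lower from compound 1 to compound 4 (within the scatter), and this is the first single-place change shown on the ring that carries the methoxy groups. It gives a direct reading at this position: with the 4-aminophenyl on the carbonyl carbon held constant, hydrogen can stand in place of the methoxy group that sat ortho to a methoxy group and meta to a large group, and compound 1 and compound 4 cannot be told apart at the concentration tested. No measurement shown here offers an explanation for this result.

Whether this position accepts anything other than methoxy or hydrogen stays open, since a hydroxyl group, an ethoxy group or an amine on this aromatic carbon is not among the compounds shown. Also open, from the compounds shown here alone, is whether the same change would leave the read-out as little moved with 3,4-dichlorophenyl on the carbonyl carbon, as in compound 3 at -10%, and whether compound 1 and compound 4 would differ in potency, which a read-out at one concentration cannot show.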